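Trading an aromatic amine for dipropylamine on a shared core

The source may hold more compounds than are shown below. What is called first, only, known or untested is meant among the compounds shown, and "the series" means these compounds.

Compound 1, `COc1ccccc1NC1=CC(=O)c2c(nc3n2[C@H]2OC[C@@H](O)[C@H]2OC3)C1=O`, gives 7460 nM in a functional assay on HeLa cells (Homo sapiens) for inhibition, read by sulforhodamine B assay; on this read-out lower numbers stand for stronger inhibition and higher numbers for weaker inhibition.
Compound 2, `CCOc1ccc(NC2=CC(=O)c3c(nc4n3[C@H]3OC[C@@H](O)[C@H]3OC4)C2=O)cc1`, gives 14400 nM in this assay.

Compound 1 holds the lower of the two numbers, but the step of a 1.9-fold higher number from compound 1 to compound 2 (0.29 log units; within the scatter) means the two compounds cannot be told apart on this read-out. Compound 3, `CCCN(CCC)C1=CC(=O)c2c(nc3n2[C@H]2OC[C@@H](O)[C@H]2OC3)C1=O`, has not yet been measured. Relative to compound 1 it carries dipropylamino in place of (2-methoxyphenyl)amino on a double-bonded ring carbon. Within the data shown here, the one measured step, a 1.9-fold higher number from compound 1 to compound 2 (0.29 log units; within the scatter), kept the aromatic ring and its amine hydrogen and only moved and lengthened the alkoxy group, so it speaks to a different kind of change and gives no direct guide here. Among the measured compounds shown here, no measured step bears on removing the ring and the hydrogen-bond donor. With that gap in the data, the expectation is a number near that of compound 1, or somewhat higher, with a wide range. Compound 3 is expected to give 12000 nM, between 3000 nM and 50000 nM. This estimate means an expected 1.6-fold higher number from compound 1 to compound 3 (0.21 log units; within the scatter), a step that may or may not exceed the scatter.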

Compound 3, half-maximal inhibitory concentration: > 16000 nM
Compound 3 was reported as a limit (the forecaster's own chance of this, stated with the estimate: 15%); at least 1.3-fold (0.12 log units) between middle value and limit.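

Replacing (2-methoxyphenyl)amino with dipropylamino on the double-bonded ring carbon removes both the aromatic ring and the amine hydrogen, and in this assay this change gives an at least 2.1-fold higher number from compound 1 to compound 3 (0.33 log units; beyond the scatter). Among these compounds, the earlier comparison, a 1.9-fold higher number from compound 1 to compound 2 (0.29 log units; within the scatter), kept the ring and the amine hydrogen and could not separate its two compounds, so this is the first sign that the read-out responds to the group at this position, with the change here going toward weaker inhibition. The figure for compound 3 is a limit of the assay and not an exact number, so the step has a minimum size but no known full size: the limit of > 16000 nM in this assay, at which 1 of the 3 values shown sits.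

Because the ring and the amine hydrogen leave together, the data cannot say which loss matters, or whether the dipropylamino group itself is responsible: the limit of > 16000 nM in this assay, at which 1 of the 3 values shown sits A propylamino group would keep the amine hydrogen without the ring, while a methyl(phenyl)amino group would keep the ring without that hydrogen, so the pair could pull these two changes apart on the shared core.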